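Aryl exchange on the shared core: compound 3 to compound 4

The compounds below may be only part of what the source reports. "The series", "measured", "known", "first", "only" and "open" are said of these compounds alone.

Measured so far:
compound 1 `CC/C(=C(/c1ccc(/C=C/C(=O)O)cc1)c1cc2ccccc2[nH]1)c1cccc(OC(F)(F)F)c1` — in a functional assay on MCF7 cells (Homo sapiens) for inhibition (a higher number here means a weaker inhibitor, a lower number a stronger inhibitor), compound 1 gives 282 nM
compound 2 `CC/C(=C(/c1ccc(/C=C/C(=O)O)cc1)c1cc2ccccc2[nH]1)c1ccc(F)cc1Cl` — in this assay compound 2 gives 39 nM
compound 3 `CC/C(=C(/c1ccc(/C=C/C(=O)O)cc1)c1cc2ccccc2[nH]1)c1ccc(C#N)cc1Cl` — in this assay compound 3 gives 49 nM

Compound 3 stands second highest of the three numbers. Its nearest neighbour is compound 2, within the scatter; its furthest is compound 1, well beyond it.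

Compound 4 `CC/C(=C(/c1ccc(/C=C/C(=O)O)cc1)c1cc2ccccc2[nH]1)c1ccc(Cl)cc1C(F)(F)F` differs from compound 3 in one place: 4-chloro-2-(trifluoromethyl)phenyl in place of 2-chloro-4-cyanophenyl on a double-bonded chain carbon bound to a double-bonded chain carbon and a saturated chain carbon.

Within the data shown here, two measured steps bear on this change. a 7.2-fold lower number from compound 1 to compound 2 (0.86 log units; beyond the scatter) and a 5.8-fold lower number from compound 1 to compound 3 (0.76 log units; beyond the scatter) show that moving from the 3-(trifluoromethoxy)phenyl to either chloro-bearing aryl brought a modest gain. a 1.3-fold higher number from compound 2 to compound 3 (0.10 log units; within the scatter) shows that swapping cyano for fluoro on that aryl made no difference beyond the scatter. Among the measured compounds shown here, no measured pair exchanges chloro for trifluoromethyl or shifts the pattern in the way compound 4 does, so the new aryl is judged only as a third chloro-bearing aryl of the same kind. On that basis no step beyond the scatter is expected, and the step from compound 3 to compound 4 in this assay is estimated at a 1.2-fold higher number from compound 3 to compound 4 (0.09 log units; within the scatter).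

Compound 4 is therefore expected to give about 60 nM in this assay, with a plausible range from 20 nM to 180 nM.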

Compound 4, half-maximal inhibitory concentration: 4 nM
Beside the measured number, compound 4's estimate is 15-fold (1.18 log units) above it, outside the stated range (below it).
By their numbers in this assay, from the lowest: compound 4; then compounds 2 and 3 (each within the scatter of the next); then compound 1.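

In this assay, among these compounds, the aryl on the double-bonded chain carbon proves more sensitive than the earlier compounds suggested: the exchange between compound 2 and compound 3 stayed within the scatter, yet 4-chloro-2-(trifluoromethyl)phenyl in place of 2-chloro-4-cyanophenyl gives a 12-fold lower number from compound 3 to compound 4 (1.09 log units; beyond the scatter), and in place of 2-chloro-4-fluorophenyl it gives a 9.8-fold lower number from compound 2 to compound 4 (0.99 log units; beyond the scatter). Chloro-bearing aryls are therefore not interchangeable here, and the range at this position widens to a 71-fold lower number from compound 1 to compound 4 (1.85 log units; beyond the scatter) when 3-(trifluoromethoxy)phenyl is the group replaced. No evidence is available to explain the gain.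

Compound 4 differs from compound 2 and compound 3 in both the chloro placement and the second substituent, so the gain cannot be assigned to the trifluoromethyl or to the chloro placement alone. A bromo or methyl group in place of the trifluoromethyl of 4-chloro-2-(trifluoromethyl)phenyl would show whether the gain is specific to trifluoromethyl or extends to other groups at that place on the aryl.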